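The source may report more compounds than this note shows. Statements on the series, on what has been measured and on what is new or still open speak of the compounds shown alone.

Of the compounds shown here, two that share one core have been tested in an ADME assay on L6 cells (Rattus norvegicus) for cytotoxicity; on this read-out lower numbers stand for stronger inhibition and higher numbers for weaker inhibition. Compound 1, `O=C(NCCCN1CCN(CCCNc2ccnc3cc(Cl)ccc23)CC1)c1ccc(Oc2ccccc2)cc1`, gives 1400 nM in this assay. Compound 2, `O=C(CCCc1c[nH]c2ccccc12)NCCCN1CCN(CCCNc2ccnc3cc(Cl)ccc23)CC1`, gives 6500 nM in this assay. Compound 2 therefore stands at the higher of the two numbers, which here means the weaker inhibition of the cells, and its gap to compound 1 lies beyond the usual scatter of repeated measurements.

Compound 3, `O=C(CCCCc1ccccc1)NCCCN1CCN(CCCNc2ccnc3cc(Cl)ccc23)CC1`, has not yet been measured. It differs from compound 2 in a single place: benzyl in place of 1H-indol-3-yl on a saturated chain carbon, three bonds along the chain from a carbonyl carbon. For the measured compounds named here, no pair of measured compounds shows this same change, so there is no earlier step to lean on; the only guidance is the two numbers already seen and the modest size of the swap. The step is expected to be small, a 1.2-fold higher number from compound 2 to compound 3 (0.09 log units; within the scatter), a shift that stays within the scatter. On that basis compound 3 is estimated to give about 8000 nM in this assay, with a likely range from 3000 nM to 20000 nM.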

Compound 3, half-maximal inhibitory concentration: 9400 nM
Compound 3: middle estimate off by 1.2-fold (0.07 log units), on the low side; measured number inside the range.
By their numbers in this assay, from the lowest: compound 1; then compounds 2 and 3 (each within the scatter of the next).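

The step in this assay is a 1.4-fold higher number from compound 2 to compound 3 (0.16 log units; within the scatter) and so gives no real separation between the two compounds on this read-out. For the compounds shown here, this is the first view of this position, on a saturated chain carbon, three bonds along the chain from a carbonyl carbon. Here, 1H-indol-3-yl, with its five-membered aromatic ring, nitrogen and hydrogen-bond donor, can be replaced by benzyl, which has none of these, without a change that can be told from the scatter. Nothing in the data given here accounts for this result.

On these data alone, it remains open how a group of a different kind at this place, such as an amine or a carboxylic acid, would read in this assay and whether it would move the number beyond the scatter. This is also a single pair on one core, so it leaves open whether a longer chain carrying the same aromatic groups, or the same swap made elsewhere in the molecule, would behave in the same way.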